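A few compounds are considered here, and "the series" means these few. Any claim that something is new, unique, unknown or untested is made for them only; others in the source may bear on it.

In an assay on microsomes from liver for inhibition of 3-hydroxy-3-methylglutaryl-coenzyme A reductase (Sus scrofa), read by colorimetric assay (on this read-out lower numbers stand for stronger inhibition and higher numbers for weaker inhibition), compound 2 `CCc1ccc([C@H]2C=C(CC/C=C(\C)CCC=C(C)C)C(=O)O2)cc1` gives 14200 nM, and compound 1 `CC(C)=CCC/C(C)=C/CCC1=C[C@H](c2ccc(C)cc2)OC1=O` gives 18100 nM in this assay; the two stand within the scatter of each other, as seen in a 1.3-fold lower number from compound 1 to compound 2 (0.11 log units; within the scatter). Compound 3 `CC(C)=CCC/C(C)=C/CCC1=C[C@H](c2ccc([N+](=O)[O-])cc2)OC1=O` differs from compound 2 by nitro in place of ethyl on an aromatic carbon. Within the data shown here, only that one measured step concerns a group on the same aromatic ring, and it stayed within the scatter; no measured step exchanges a carbon group for a nitro group, so the expected step of a 1.1-fold higher number from compound 2 to compound 3 (0.02 log units; within the scatter) is none beyond the scatter, with a wide range. Compound 3 is estimated at 15000 nM in this assay, between 5000 nM and 45000 nM.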

Compound 3, half-maximal inhibitory concentration: 7430 nM
For compound 3 the middle estimate is 2.0-fold (0.31 log units) above the measured one; low and high end bracket the measured number.
By their numbers in this assay, from the lowest: compounds 3, 2 and 1 (each within the scatter of the next, the first and the last beyond it).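

In this assay, nitro in place of ethyl on the aromatic carbon gives a 1.9-fold lower number from compound 2 to compound 3 (0.28 log units; within the scatter) and stays within the scatter, while nitro in place of methyl gives a 2.4-fold lower number from compound 1 to compound 3 (0.39 log units; beyond the scatter) and is a modest step beyond it. Among these compounds, this is the first step at this position, para to a large group, to pass the scatter, and the first to put a group with nitrogen and oxygen there instead of a carbon group. Nothing available explains this step.

As far as these compounds go, how an amine, a carboxylic acid or a longer chain at this same place would compare remains open.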